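Methyl for Methoxy on an Aromatic Ring

The source may report more compounds than this note shows. Statements on the series, on what has been measured and on what is new or still open speak of the compounds shown alone.

Of the compounds shown here, two of one series have been measured in a functional assay on C6 cells (Rattus norvegicus) for cytotoxicity, read by MTT assay, with a stated time of 24 h, tested at 100 ug/mL; on this read-out higher numbers stand for a weaker effect at the one concentration tested and lower numbers for a stronger effect. Compound 1 `Cc1nnc(SCC(=O)N/N=c2/scc(-c3ccc(F)cc3)n2-c2ccccc2)s1` gives 34.9% in this assay, and compound 2 `COc1ccc(-c2cs/c(=N/NC(=O)CSc3nnc(C)s3)n2-c2ccccc2)cc1` gives 25.9%. They differ in one place only, methoxy in place of fluoro on an aromatic carbon, and the step of a number 9 percentage points lower from compound 1 to compound 2 (within the scatter) lies within the scatter, so the two cannot be told apart. Among the measured compounds shown here, that is where compound 2 stands: its only neighbour on these numbers is compound 1, and nothing separates them beyond the usual spread of repeated measurements.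

Compound 3 `Cc1ccc(-c2cs/c(=N/NC(=O)CSc3nnc(C)s3)n2-c2ccccc2)cc1` is the next member and has not yet been measured in this assay. Its difference from compound 2 is methyl in place of methoxy on an aromatic carbon, that is, 4-methoxyphenyl to 4-methylphenyl. For the measured compounds named here, the one measured step, from compound 1 to compound 2, touched the same aromatic carbon and stayed within the scatter; no measured step concerns methyl in place of methoxy. A step within the scatter is therefore expected, a number 3.1 percentage points higher from compound 2 to compound 3 (within the scatter), in this assay. Compound 3 is expected to give 29%, between 15% and 45%.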

Compound 3, a percentage reported as activity, at one concentration (the size of the read-out at that concentration, not a potency): 31.5%
The estimate for compound 3 lay 2.5 percentage points below the measured number; measured number inside the range.
By their numbers in this assay, from the lowest: compounds 2, 3 and 1 (each within the scatter of the next).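

In this assay the exchange of 4-methoxyphenyl for 4-methylphenyl, on an aromatic carbon para to a large group, reads as a number 5.6 percentage points higher from compound 2 to compound 3 (within the scatter), so this second change at the same carbon also cannot be told from repeated-measurement spread. The comparison of methyl with fluoro at that carbon reads as a number 3.4 percentage points lower from compound 1 to compound 3 (within the scatter), which means that all three pairs among fluoro, methoxy and methyl now lie within the scatter, and these three groups give no ranking at this position in this assay. Nothing measured alongside these numbers offers an explanation for them.

The compounds shown leave open whether an amine, a carboxylic acid or a longer chain such as butoxy on this same aromatic carbon would give a number clearly apart from these three. They also share everything outside this one position and were read at a single concentration, so they cannot show whether the same closeness would hold for changes elsewhere on the shared core or as a measure of potency.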